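From Hydroxy to Methoxy on the Shared Core

The source may hold more compounds than are shown below. What is called first, only, known or untested is meant among the compounds shown, and "the series" means these compounds.

Within the data shown here, in an ADME assay on THP-1 cells (Homo sapiens) for cytotoxicity, read by flow cytometry and propidium iodide staining, with a stated time of 72 h (a lower number here means a stronger inhibitor, a higher number a weaker inhibitor), compound 3 (`Nc1ccc2oc(-c3ccc(F)cc3)c(O)c(=O)c2c1`) gives 4000 nM and holds the lowest of the three numbers measured so far. Compound 1 (`CC(=O)Nc1ccc2oc(-c3ccc(F)cc3)c(O)c(=O)c2c1`) gives 26000 nM there, and compound 2 (`Nc1ccc2oc(-c3ccccc3)c(O)c(=O)c2c1`) gives 27000 nM there. Compound 4 (`COc1c(-c2ccc(F)cc2)oc2ccc(N)cc2c1=O`) differs from compound 3 by methyl in place of hydrogen on an oxygen on an aromatic ring, which reads hydroxy to methoxy (methyl in place of hydrogen on an oxygen on an aromatic ring). Among the measured compounds shown here, no measured step touches that oxygen, so the evidence is indirect and speaks mainly to size. Two modest steps elsewhere on the shared core lie beyond the scatter: hydrogen in place of acetyl shows a 6.5-fold lower number from compound 1 to compound 3 (0.81 log units; beyond the scatter) and fluoro in place of hydrogen shows a 6.8-fold lower number from compound 2 to compound 3 (0.83 log units; beyond the scatter) in turn. Since compound 3 at 4000 nM sits lowest, a change away from it is expected to raise the number modestly, though with little certainty. The expected change is a 2.5-fold higher number from compound 3 to compound 4 (0.40 log units; beyond the scatter) in this assay on this reasoning. Compound 4 is estimated at 10000 nM (expected range 2500 nM to 40000 nM).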

Compound 4, half-maximal inhibitory concentration: 36000 nM
Compound 4: middle estimate off by 3.6-fold (0.56 log units), on the low side, and the stated range covers the measured number.
By their numbers in this assay, from the lowest: compound 3; then compounds 1, 2 and 4 (each within the scatter of the next).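

Among these compounds, this is the first measured change at this oxygen, and in this assay the hydroxy to methoxy swap gives a 9.0-fold higher number from compound 3 to compound 4 (0.95 log units; beyond the scatter), a rise that lies beyond the scatter. The earlier steps shown here changed only the acetyl on the nitrogen and the fluoro on the aromatic carbon, so this result adds that the number also responds at the oxygen on the aromatic ring, here to the entry of a single methyl in place of a hydrogen. Nothing measured on these compounds explains the rise.

The compounds shown leave open whether an ethyl group, an acetyl group or a longer chain on that oxygen would raise the number as methyl does. They also leave open whether the fluoro and acetyl steps would hold on a core that carries the methoxy group.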